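Nitro in Place of Methoxy on a Second Core

The compounds below may be only part of what the source reports. "The series", "measured", "known", "first", "only" and "open" are said of these compounds alone.

Three compounds have been measured in a functional assay on MDA-MB-231 cells (Homo sapiens) for antiproliferative activity, read by sulforhodamine B assay; on this read-out higher numbers stand for weaker inhibition of growth and lower numbers for stronger inhibition of growth:

Compound 1 `COc1ccc(C(=O)Nc2nc3cc(C)cc(C)c3s2)cc1` gives 1.03 ug/mL.
Compound 2 `COc1ccc(C(=O)Nc2nc3cc(OC)ccc3s2)cc1` gives only a limit of the assay, > 10 ug/mL.
Compound 3 `Cc1cc(C)c2sc(NC(=O)c3ccc([N+](=O)[O-])cc3)nc2c1` gives 0.29 ug/mL.

Compound 3 arises from compound 1 by nitro in place of methoxy on an aromatic carbon, and that change brings a 3.6-fold lower number from compound 1 to compound 3 (0.55 log units; beyond the scatter). Compound 2 and compound 1 carry different cores; the difference between the two cores is not broken down here. Compound 4 `COc1ccc2sc(NC(=O)c3ccc([N+](=O)[O-])cc3)nc2c1`, not yet measured, arises from compound 2 by nitro in place of methoxy on an aromatic carbon, the same kind of change, and the two place descriptions agree word for word.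

Since compound 2 sits at the limit of > 10 ug/mL in this assay, at which 1 of the 3 values shown sits, the size of the step to compound 4 in this assay cannot be fixed from a number. The step meant here, an at least 2.0-fold lower number from compound 2 to compound 4 (0.30 log units; that floor lies within the scatter), is expected to resemble the step from compound 1 to compound 3 in direction, with more uncertainty. Compound 4 is estimated at 5 ug/mL, in a range from 1.5 ug/mL to 20 ug/mL.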

Compound 4, concentration for 50% growth inhibition: > 10 ug/mL
Compound 4 gave a limit, no number; the forecaster's own chance of this, stated with the estimate: 40%; middle value at least 2.0-fold (0.30 log units) away from the limit.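

In this assay, compound 2 and compound 4 both stand at a limit, so no step between them can be read: the limit of > 10 ug/mL in this assay, at which 2 of the 4 values shown sit.

On these data alone, whether nitro in place of methoxy lowers the number on the core of compound 2, as it does on the core of compound 1, stays open.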